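The source may report more compounds than this note shows. Statements on the series, on what has been measured and on what is new or still open speak of the compounds shown alone.

Compound 2 `COc1cc2c(Oc3ccc(NC(=O)c4nnn(-c5ccccc5)c4C)cc3F)ccnc2cc1OCCCN1CCCCC1` gives the lowest of the two numbers in a functional assay on A549 cells (Homo sapiens) for cytotoxicity, read by MTT assay, with a stated time of 72 h (a higher number here means a weaker inhibitor, a lower number a stronger inhibitor), with 100 nM. Among the measured compounds shown here, compound 1 `COc1cc2c(Oc3ccc(NC(=O)c4nnn(-c5ccccc5C)c4C)cc3F)ccnc2cc1OCCCN1CCCCC1` gives 330 nM, and the only measured step, a 3.3-fold lower number from compound 1 to compound 2 (0.52 log units; beyond the scatter), concerns a methyl on an aromatic carbon. For the measured compounds named here, compound 3 `COc1cc2c(Oc3ccc(NC(=O)c4nnn(-c5ccccc5)c4C)cc3F)ccnc2cc1OCCCN1CCC(C)CC1` differs from compound 2 by methyl in place of hydrogen on a saturated ring carbon, a change at a different place, so no measured step bears directly on it and no step beyond the scatter is expected. For compound 3 the expected step is a 1.1-fold higher number from compound 2 to compound 3 (0.04 log units; within the scatter). Compound 3 is therefore estimated at 110 nM, within a range from 45 nM to 270 nM.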

Compound 3, half-maximal inhibitory concentration: 110 nM
Beside the measured number, compound 3's estimate shows no gap at the digits printed; measured number inside the range.
By their numbers in this assay, from the lowest: compounds 2 and 3 (each within the scatter of the next); then compound 1.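

The step to 4-methylpiperidin-1-yl, a 1.1-fold higher number from compound 2 to compound 3 (0.04 log units; within the scatter) in this assay, shows that this saturated ring carbon, three ring bonds from the ring nitrogen, can carry a methyl with no change beyond the scatter. The earlier step concerned a methyl on an aromatic carbon, so it said nothing about this ring. No measurement shown accounts for this result.

From the compounds shown here alone, whether the same ring carbon would accept something larger than methyl, such as a phenyl group, or a hydroxyl or an amine, remains open. The compounds shown also leave open how a morpholine ring would compare with the piperidine ring.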